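Swapping the Oxime Ether Substituent for Isopropyl

The compounds below may be only part of what the source reports. "The series", "measured", "known", "first", "only" and "open" are said of these compounds alone.

Measured compounds:
Compound 1, `CS/C(=N\O)c1ccc(Sc2cc(F)cc(C3CCOCC3)c2)cc1`, gives 190 nM.
Compound 2, `COC(=O)c1cc(CO/N=C(\C)c2ccc(Sc3cc(F)cc(C4CCOCC4)c3)cc2)on1`, gives 100 nM.

Both values come from a functional assay (blood) for inhibition, with Homo sapiens as the target; a higher number here means a weaker inhibitor, a lower number a stronger inhibitor. Compound 2 shows the lowest of the two numbers, yet its gap to compound 1 lies within the scatter of repeated measurements, so neither compound can be called stronger or weaker than the other. Compound 1 and compound 2 also differ from each other in more than one place, so no single structural step can be read from their pair.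

Compound 3, `C/C(=N\OC(C)C)c1ccc(Sc2cc(F)cc(C3CCOCC3)c2)cc1`, differs from compound 2 only on the oxygen of the oxime ether: isopropyl in place of (3-(methoxycarbonyl)-1,2-oxazol-5-yl)methyl on an oxygen. A large substituent on that oxygen is thus traded for a small one.

Within the data shown here, with only two measured compounds, whose values sit within the scatter of each other, and no single-change step to lean on, the expected change is modest: the step of a 2.0-fold higher number from compound 2 to compound 3 (0.30 log units; within the scatter) is estimated to fall close to the scatter, leaning toward a slightly higher number. Compound 3 is therefore expected to give about 200 nM in this assay, with a likely range from 70 nM to 600 nM.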

Compound 3, half-maximal inhibitory concentration: 920 nM
Beside the measured number, compound 3's estimate is 4.6-fold (0.66 log units) below it; the whole stated range lies below it.
By their numbers in this assay, from the lowest: compounds 2 and 1 (each within the scatter of the next); then compound 3.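

In this assay, the group on the oxygen bound to the double-bonded nitrogen turns out to matter: putting isopropyl in place of (3-(methoxycarbonyl)-1,2-oxazol-5-yl)methyl gives a 9.2-fold higher number from compound 2 to compound 3 (0.96 log units; beyond the scatter) and so moves the number well past the scatter. Among these compounds, this is the first single-place step, and it shows that this oxygen's substituent can change the result, with the larger group giving the lower number of the pair. The comparison with compound 1, which carries a different group on the aromatic carbon, points the same way, with a 4.8-fold higher number from compound 1 to compound 3 (0.69 log units; beyond the scatter) making compound 3 the weakest inhibitor of the three shown.

Going by these compounds, the step removes the ring, the ester and the isopropyl-free chain all at once, so it remains open whether the whole leaving group is needed, or whether a benzyl group or a carboxylic acid in place of the methyl ester would keep the lower number. Nothing in the data shown explains why the number rises with this change.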